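Replacing the bromo of compound 3 with hydrogen

The source may report more compounds than this note shows. Statements on the series, on what has been measured and on what is new or still open speak of the compounds shown alone.

Measured in a functional assay on NCI-H460 cells (Homo sapiens) for inhibition, read by sulforhodamine B assay, with a stated time of 48 h; a lower number here means a stronger inhibitor of growth, a higher number a weaker inhibitor of growth:
Compound 1 `CC(C)(C)NCc1c(C(=O)O)nn(-c2ccccc2)c1-c1ccccc1`: > 716000 nM, a limit
Compound 2 `CC(C)(C)NCc1c(C(=O)O)nn(-c2ccc(Cl)cc2)c1-c1ccc(Cl)cc1`: > 599000 nM, a limit
Compound 3 `CC(C)(C)NCc1c(C(=O)O)nn(-c2ccc(Cl)cc2)c1-c1ccc(Br)cc1`: > 542000 nM, a limit

In this assay compound 3 stands only at a limit, > 542000 nM. Neither of the other two measured compounds gives a number either. Compound 4 `CC(C)(C)NCc1c(C(=O)O)nn(-c2ccc(Cl)cc2)c1-c1ccccc1` has hydrogen in place of bromo on an aromatic carbon, para to a large group (hydrogen in place of bromo on an aromatic carbon). Going by the values given here, the one measured step bearing on this is a step that the two limits leave unreadable from compound 2 to compound 3, so it gives neither a size nor a direction. No change beyond the scatter is expected, and the expected step is a step that the limit leaves unreadable from compound 3 to compound 4. Compound 4 is estimated at 650000 nM, within an expected range of 400000 nM to 800000 nM, and will probably also be reported only as a limit.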

Compound 4, concentration for 50% growth inhibition: > 652000 nM
Compound 4 gave a limit, no number; the forecaster's own chance of this, stated with the estimate: 90%; middle value at least 1.0-fold (0.00 log units) from the limit.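

In this assay compound 4 gives only a limit, > 652000 nM. Going by these compounds alone, compound 1, compound 2 and compound 3 also stand at limits, so no step to compound 4 can be read. The compounds shown leave open whether bromo, chloro or hydrogen on an aromatic carbon makes any difference in this assay.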